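Aryl substituent swap on a pyrrolidine amide series

A few compounds are considered here, and "the series" means these few. Any claim that something is new, unique, unknown or untested is made for them only; others in the source may bear on it.

Measured compounds: compound 1 `O=C(CCCCCCc1cccc(F)c1)N1CCCC1`, compound 2 `O=C(CCCCCCc1ccc(O)cc1)N1CCCC1`, compound 3 `CCCc1cccc(CCCCCCC(=O)N2CCCC2)c1`. In an assay on HEK293 cells for inhibition of N-acylethanolamine-hydrolyzing acid amidase (Rattus norvegicus), read by LC-MS, with a stated time of 30 min (a higher number here means a weaker inhibitor, a lower number a stronger inhibitor), compound 1 gives 7300 nM. In this assay compound 2 gives 5600 nM. For compound 3 the result in this assay is a limit, > 100000 nM, not a number.

Compound 2 stands as the lowest of the two numbers; compound 1 is the nearest, within the scatter. Compound 4 `CCCc1ccc(CCCCCCC(=O)N2CCCC2)cc1` is not yet measured. The change is propyl in place of hydroxy on an aromatic carbon. Among the compounds with values here, the one measured step that bears on it, an at least 13-fold higher number from compound 1 to compound 3 (1.13 log units; beyond the scatter), also put propyl onto the aromatic ring and ran to the limit (the limit of > 100000 nM in this assay, at which 1 of the 3 values shown sits). A large rise is therefore expected for compound 4, an 18-fold higher number from compound 2 to compound 4 (1.25 log units; beyond the scatter). For compound 4 the estimate in this assay is 100000 nM, between 30000 nM and 300000 nM.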

Compound 4, half-maximal inhibitory concentration: > 100000 nM
Compound 4 was reported as a limit; the forecaster's own chance of this, stated with the estimate: 60%; the middle value lies on the limit itself.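

Propyl in place of hydroxy, para to a large group, gives an at least 17-fold higher number from compound 2 to compound 4 (1.25 log units; beyond the scatter). In this assay compound 4 gives > 100000 nM, which is a limit and not a number. Propyl on the aromatic ring now reaches this limit from a hydroxy compound as well as from a fluoro compound, and at a second ring place: the limit of > 100000 nM in this assay, at which 2 of the 4 values shown sit.

Still open, as far as these compounds go, is whether a smaller methyl or ethyl group at this place would keep the number close to that of compound 2. Also open, from the compounds shown here alone, is what a methoxy group, an amine or a carboxylic acid would do there.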